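Swapping a chain for a ring on compound 2

The source may report more compounds than this note shows. Statements on the series, on what has been measured and on what is new or still open speak of the compounds shown alone.

Three related compounds have been given to rats so far, and the read-out is an ADME assay on the whole organism for pharmacokinetics, with Rattus norvegicus as the target, at a dose of 5 mg/kg by the oral route (a lower number here means less compound in the circulation, a higher number more compound in the circulation at the dose given), in each case. Compound 1 (`CC(C)(O)c1ccc(-c2cnc3c(n2)N(CCC2CCOCC2)C(=O)CN3)cn1`) reaches 1700 nM in this measure, and compound 3 (`CO[C@H]1CC[C@@H](N2CC(=O)Nc3ncc(-c4ccc(C(C)(C)O)nc4)nc32)CC1`) reaches 2770 nM on the same scale. Compound 2 (`COCCN1C(=O)CNc2ncc(-c3ccc(C(C)(C)O)nc3)nc21`) stands highest of the three at 5600 nM and is the starting point here.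

Compound 4 (`CO[C@H]1CC[C@H](N2C(=O)CNc3ncc(-c4ccc(C(C)(C)O)nc4)nc32)CC1`) keeps the core of compound 2 and changes one group, with 4-methoxycyclohexyl in place of 2-methoxyethyl on an amide-type nitrogen in a ring.

Among the measured compounds shown here, one measured step bears directly on this change. It sits two bonds along the chain from the same nitrogen. Putting methoxy in place of oxan-4-yl gave a 3.3-fold higher number from compound 1 to compound 2 (0.52 log units; beyond the scatter) and so the chain with the ring gave the lower number. Compound 3 also carries a 4-methoxycyclohexyl group, though on a differently arranged core, and its 2770 nM likewise lies under the top value.

On these few compounds, a modest fall is expected in this assay and the estimated change is a 2.0-fold lower number from compound 2 to compound 4 (0.30 log units; within the scatter) with real uncertainty around it. The estimate for compound 4 is 2800 nM within an expected range of 1100 nM to 7000 nM.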

Compound 4, maximal plasma concentration: 2900 nM
Estimate against measurement, compound 4: 1.0-fold (0.02 log units) below, within the range that was stated.
By their numbers in this assay, from the lowest: compounds 1, 3, 4 and 2 (each within the scatter of the next, the first and the last beyond it).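

On the amide-type nitrogen in a ring, the open 2-methoxyethyl chain can give way to 4-methoxycyclohexyl, with its six-membered carbon ring, and in this assay the swap gives a 1.9-fold lower number from compound 2 to compound 4 (0.29 log units; within the scatter) and so cannot be told apart from repeat measurements. Set against the other ring-bearing group at this nitrogen, 2-(oxan-4-yl)ethyl, the same group gives a 1.7-fold higher number from compound 1 to compound 4 (0.23 log units; within the scatter) and is again not separable, which leaves compound 4 unresolved from both of two compounds that the earlier step of a 3.3-fold higher number from compound 1 to compound 2 (0.52 log units; beyond the scatter) did separate. Nothing available here accounts for these numbers.

From the compounds shown here alone, whether a small methyl group, or a cyclohexyl ring carrying an amine or a carboxylic acid in place of methoxy, would keep the number at this level on the same nitrogen remains open. Also open, going by these compounds, is how the other spatial form of 4-methoxycyclohexyl would behave on this core, and whether peak concentration in the rat says anything about how long these compounds stay in the circulation.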